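The compounds below may be only part of what the source reports. "The series", "measured", "known", "first", "only" and "open" are said of these compounds alone.

- compound 1 `Cn1cnc(S(=O)(=O)N2C[C@@H]3[C@H](C2)[C@@]3(CNC(=O)c2cc(Cl)cc(Cl)c2)CC2CC2)c1`: 0.02
- compound 2 `Cn1cnc(S(=O)(=O)N2C[C@@H]3[C@H](C2)[C@@]3(CNC(=O)c2ccccc2C(F)(F)F)CC2CC2)c1`: 0.07
- compound 3 `Cn1cnc(S(=O)(=O)N2C[C@@H]3[C@H](C2)[C@@]3(CNC(=O)c2cccc(C(F)(F)F)c2)CC2CC2)c1`: 0.04

In an ADME assay on a cell-free system (plasma, Homo sapiens) for protein binding (a lower number here means a smaller unbound share, a higher number a larger unbound share of the compound), compound 3 gives 0.04, within the scatter of both other compounds: a 2.0-fold higher number from compound 1 to compound 3 (0.30 log units; within the scatter) and a 1.8-fold lower number from compound 2 to compound 3 (0.24 log units; within the scatter). Compound 4 `Cn1cnc(S(=O)(=O)N2C[C@@H]3[C@H](C2)[C@@]3(CNC(=O)c2ccc(Cl)cc2Cl)CC2CC2)c1` brings one change: 2,4-dichlorophenyl in place of 3-(trifluoromethyl)phenyl on a carbonyl carbon. It has 2,4-dichlorophenyl in place of 3-(trifluoromethyl)phenyl on a carbonyl carbon. Swaps at this place have so far moved the number only slightly, the largest being a modest 3.5-fold higher number from compound 1 to compound 2 (0.54 log units; beyond the scatter). Among the compounds with values here, compound 1, the one measured dichlorophenyl compound, gives 0.02, so the estimate leans slightly low, but no step beyond the scatter is expected. The expected step is a 1.3-fold lower number from compound 3 to compound 4 (0.12 log units; within the scatter). The estimate for compound 4 is 0.03, with an expected range of 0.015 to 0.06.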

Compound 4, unbound fraction: 0.05
Compound 4: the middle estimate sits 1.7-fold (0.22 log units) below what was measured, and the stated range covers the measured number.
By their numbers in this assay, from the lowest: compounds 1, 3, 4 and 2 (each within the scatter of the next, the first and the last beyond it).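

In this assay the two dichlorophenyl compounds differ, showing a 2.5-fold higher number from compound 1 to compound 4 (0.40 log units; beyond the scatter) and so two chlorines alone do not fix the number at this position. The 2,4-dichlorophenyl compound also sits with the two trifluoromethyl compounds, showing a 1.3-fold higher number from compound 3 to compound 4 (0.10 log units; within the scatter) and a 1.4-fold lower number from compound 2 to compound 4 (0.15 log units; within the scatter) with no clean split between chlorine and trifluoromethyl groups.

From the compounds shown here alone, whether a phenyl ring carrying an amine or a carboxylic acid would shift the unbound share at this position stays open. Nothing measured here explains the difference between the two chlorine patterns.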